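The source may hold more compounds than are shown below. What is called first, only, known or untested is meant among the compounds shown, and "the series" means these compounds.

Compound 1 `Nc1ccc(/C=C2\SC(=O)N(Cc3ccc(Cl)cc3)C2=O)cc1` is one of three compounds built on a shared core. In a functional assay on HeLa cells (Homo sapiens) for cytotoxicity, read by cell counting, with a stated time of 4 days (a higher number here means a weaker inhibitor, a lower number a stronger inhibitor), compound 1 gives 77000 nM, the lowest of the three numbers, though within the scatter of both others: compound 3 `Nc1cccc(/C=C2\SC(=O)N(Cc3ccc(F)cc3)C2=O)c1` gives 86000 nM and compound 2 `CC(C)(C)c1ccc(CN2C(=O)S/C(=C\c3cccc(N)c3)C2=O)cc1` gives 145000 nM. Compound 4 `CN1C(=O)S/C(=C\c2ccc(N)cc2)C1=O` has not yet been measured; it differs from compound 1 by hydrogen in place of 4-chlorophenyl on a saturated chain carbon bound to an amide-type nitrogen in a ring. Going by the values given here, the only measured step touching that group, a 1.7-fold lower number from compound 2 to compound 3 (0.23 log units; within the scatter), exchanged one group on an aromatic carbon for another but kept the ring, so it bears only loosely on a change that removes the ring entirely. In this assay a step of a 1.9-fold higher number from compound 1 to compound 4 (0.29 log units; within the scatter) is therefore expected, toward a higher number with wide uncertainty, giving compound 4 an estimated 150000 nM, between 50000 nM and 500000 nM.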

Compound 4, half-maximal inhibitory concentration: 97000 nM
Compound 4: middle estimate off by 1.5-fold (0.19 log units), on the high side; the measured number falls inside the stated range.
By their numbers in this assay, from the lowest: compounds 1, 3, 4 and 2 (each within the scatter of the next).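

In this assay, going by these compounds alone, the earlier compounds all kept an aromatic ring on this saturated chain carbon, so they could not show what losing it does. Here hydrogen in place of 4-chlorophenyl gives a 1.3-fold higher number from compound 1 to compound 4 (0.10 log units; within the scatter), so the whole ring can go without moving the number beyond the usual scatter. Nothing available explains this result. Still open, as far as these compounds go, is whether a longer chain, an amine or a carboxylic acid at this place would shift the number beyond the scatter.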